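Replacing 3-methylbenzyl with phenylsulfonyl in compound 1

This account rests on a few compounds, and the source may have more. Where it says the series, first, only, none or still open, it means among the compounds named here.

In a functional assay on Jurkat cells (Homo sapiens) for antiproliferative activity, read by MTT assay and trypan blue exclusion, with a stated time of 72 h (a lower number here means a stronger inhibitor, a higher number a weaker inhibitor), compound 1 `COC(=O)c1ccc(C2SCC(=O)N2c2ccc(N3CCN(Cc4cccc(C)c4)CC3)cn2)c(OC)c1` gives > 100000 nM, which is a limit of the assay and not a number. It therefore stands at the limit of > 100000 nM in this assay, at which 1 of the 2 values shown sits. Compound 3 `COC(=O)c1ccc(C2SCC(=O)N2c2ccc(N3CCN(S(=O)(=O)c4ccccc4)CC3)cn2)c(OC)c1` carries phenylsulfonyl in place of 3-methylbenzyl on an amine nitrogen in a ring. For the measured compounds named here, only one measured step alters that same group. Compound 2 `COC(=O)c1ccc(C2SCC(=O)N2c2ccc(N3CCN(Cc4ccc(Cl)c(Cl)c4)CC3)cn2)c(OC)c1` gives 61000 nM, and the step, an at least 1.6-fold lower number from compound 1 to compound 2 (0.21 log units; that floor lies within the scatter), stays within the scatter. Going by the values given here, with only that small step as a guide, the expected change in this assay is an at least 1.2-fold lower number from compound 1 to compound 3 (0.09 log units; that floor lies within the scatter), with nothing clear beyond the scatter. For compound 3 the estimated value is 80000 nM, within an expected range of 30000 nM to 150000 nM.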

Compound 3, half-maximal inhibitory concentration: 52900 nM
For compound 3 the middle estimate is 1.5-fold (0.18 log units) above the measured one; the range from low to high includes it.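

In this assay, a sulfonyl link on the amine nitrogen in the ring gives a value within the scatter of the benzyl-linked compound, seen in a 1.2-fold lower number from compound 2 to compound 3 (0.06 log units; within the scatter). Against the 3-methylbenzyl compound the change reads an at least 1.8-fold lower number from compound 1 to compound 3 (0.27 log units; that floor lies within the scatter), which is only a floor. Compound 1 stands at a limit of the assay and not a number: the limit of > 100000 nM in this assay, at which 1 of the 3 values shown sits.

Still open, as far as these compounds go, is what a small group such as acetyl or methyl would give on this nitrogen. Also open, from the compounds shown here alone, is whether a chlorine or methoxy group on the phenylsulfonyl would move the number beyond the scatter.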